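Amide variation in the series: note before compound 4

The source may hold more compounds than are shown below. What is called first, only, known or untested is meant among the compounds shown, and "the series" means these compounds.

Measured so far in a functional assay on L02 cells (Homo sapiens) for inhibition, read by MTT assay, with a stated time of 48 h; on this read-out higher numbers stand for weaker inhibition and lower numbers for stronger inhibition:
- Compound 1 `O=C(/C=C/c1coc2cc(O)ccc2c1=O)NCc1ccccc1`: the reading is a limit of the assay, > 200000 nM.
- Compound 2 `COc1cccc(NC(=O)/C=C/c2coc3cc(OC)ccc3c2=O)c1`: the reading is a limit of the assay, > 200000 nM.
- Compound 3 `COc1ccc(NC(=O)/C=C/c2coc3cc(O)ccc3c2=O)cc1`: the reading is a limit of the assay, > 200000 nM.

Within the data shown here, compound 2 stands on no scale here: its own value is a limit, and the two further values shown are limits as well, so no measured compound can be placed above or below it. All values sit at one point (the limit of > 200000 nM in this assay, at which 3 of the 3 values shown sit). Among the measured compounds shown here, the single one-place change among the measured compounds, from compound 1 to compound 3, is a step that the two limits leave unreadable from compound 1 to compound 3, and therefore yields no readable size either.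

Compound 4 `COc1ccc2c(=O)c(/C=C/C(=O)Nc3ccccc3C)coc2c1` differs from compound 2 in one place: 2-methylphenyl in place of 3-methoxyphenyl on an amide-type nitrogen. For the measured compounds named here, no measured step bears on this exchange of one substituent on the amide-type nitrogen for another, and the step from compound 1 to compound 3 cannot be read. With every value shown a limit, no direction or size of step in this assay can be expected beyond the scatter; the expectation is simply that compound 4 reads as the measured compounds do. Compound 4 is therefore estimated at 300000 nM, within 100000 nM to 1000000 nM. The implied step, a step that the limit leaves unreadable from compound 2 to compound 4, is expected to lie within the scatter, most likely reported once more only as a limit.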

Compound 4, half-maximal inhibitory concentration: > 200000 nM
Compound 4 gave a limit, no number; the forecaster's own chance of this, stated with the estimate: 85%; the middle value lies beyond the limit too.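

Compound 2 and compound 4 both read only as limits of the assay in this assay, so no step between them can be read, and the new result adds no readable size: the limit of > 200000 nM in this assay, at which 4 of the 4 values shown sit.

The compounds shown leave open whether any exchange on the amide-type nitrogen changes this read-out, and where any of them would stand on a measured scale.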